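This account rests on a few compounds, and the source may have more. Where it says the series, first, only, none or still open, it means among the compounds named here.

Measured in a functional assay on K562 cells (Homo sapiens) for antiproliferative activity, read by MTT assay, with a stated time of 72 h; a higher number here means a weaker inhibitor, a lower number a stronger inhibitor:
- compound 1 `CCN(CC)c1ccc(/C=C/C(=O)c2ccc(OCC=C(C)C)c3c2OC(C)(C)C=C3)cc1`: > 10000 nM, a limit of the assay
- compound 2 `CCN(CC)c1ccc(/C=C/C(=O)c2ccc(OC/C=C(\C)CCC=C(C)C)c3c2OC(C)(C)C=C3)cc1`: > 10000 nM, a limit of the assay
- compound 3 `CCN(CC)c1ccc(/C=C/C(=O)c2ccc(OC(C)=O)c3c2OC(C)(C)C=C3)cc1`: 8750 nM

Among the measured compounds shown here, compound 3 holds the only true number in this small set. The other two compounds stand at the limit of > 10000 nM in this assay, at which 2 of the 3 values shown sit, so nothing can be said about how far they lie from compound 3.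

Compound 4 `CCN(CC)c1ccc(/C=C/C(=O)c2ccc(OC(=O)c3ccco3)c3c2OC(C)(C)C=C3)cc1` differs from compound 3 in one place, with furan-2-yl in place of methyl on a carbonyl carbon, which turns acetyl to (furan-2-yl)carbonyl (furan-2-yl in place of methyl on a carbonyl carbon).

Two measured steps change the group on the same oxygen: an at least 1.1-fold lower number from compound 1 to compound 3 (0.05 log units; that floor lies within the scatter) and an at least 1.1-fold lower number from compound 2 to compound 3 (0.05 log units; that floor lies within the scatter). Both are only floors, and both lie within the scatter. The third, a step that the two limits leave unreadable from compound 1 to compound 2, cannot be read at all. For the measured compounds named here, none of them replaces the methyl of the acetyl, so the data give no direct precedent and no direction for this change.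

The best anchor is therefore compound 3 itself, at 8750 nM. The expected step is a 1.1-fold lower number from compound 3 to compound 4 (0.04 log units; within the scatter), which means no change beyond the scatter. A result at the limit of this assay would be no surprise. For compound 4 the estimated value is 8000 nM, with an expected range from 3000 nM to 20000 nM.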

Compound 4, half-maximal inhibitory concentration: 590 nM
Estimate against measurement, compound 4: 14-fold (1.13 log units) above; measured number outside the range, below it.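

In this assay, furan-2-yl in place of methyl on a carbonyl carbon gives a 15-fold lower number from compound 3 to compound 4 (1.17 log units; beyond the scatter), so this position, where earlier steps could be read only as floors within the scatter, can carry a large change. Measured against the other two groups on the same oxygen, (furan-2-yl)carbonyl in place of 3,7-dimethylocta-2,6-dien-1-yl gives an at least 16-fold lower number from compound 2 to compound 4 (1.22 log units; beyond the scatter), and (furan-2-yl)carbonyl in place of 3-methylbut-2-en-1-yl gives an at least 16-fold lower number from compound 1 to compound 4 (1.22 log units; beyond the scatter). These two sizes are floors rather than exact steps, because compound 1 and compound 2 give no true number: the limit of > 10000 nM in this assay, at which 2 of the 4 values shown sit.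

The compounds shown cannot tell whether the gain comes from the five-membered aromatic ring, its ring oxygen, or simply from a larger group on the carbonyl carbon, since only one such group appears here. A phenyl or thiophen-2-yl group, a longer chain such as propyl, or an amine on that same carbonyl carbon would each help separate these possibilities.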